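A Methyl-to-Ethyl Step on a Quinoline Carboxylic Acid

A few compounds are considered here, and "the series" means these few. Any claim that something is new, unique, unknown or untested is made for them only; others in the source may bear on it.

Of the compounds shown here, two have been measured in a functional assay on Hep 3B2 cells (Homo sapiens) for antiproliferative activity, read by MTT assay, with a stated time of 24 h, tested at 100 ug/mL; on this read-out lower numbers stand for a weaker effect and higher numbers for a stronger effect at the one concentration tested. Compound 1 `CCc1ccc2nc(C(=O)Nc3c(F)cc(-c4cccc(F)c4)cc3F)c(C)c(O)c2c1` gives 63.2%. Compound 2 `Cc1ccc2nc(C(=O)Nc3c(F)cc(-c4cccc(F)c4)cc3F)c(C)c(C(=O)O)c2c1` gives 75.2%, the higher of the two numbers, and the gap to compound 1 lies beyond the usual scatter. Compound 3 `CCc1ccc2nc(C(=O)Nc3c(F)cc(-c4cccc(F)c4)cc3F)c(C)c(C(=O)O)c2c1` differs from compound 2 in one place only: methyl in place of hydrogen on a saturated chain carbon bound to an aromatic carbon. For the measured compounds named here, no measured pair shows a change of exactly this kind, so the direction of its effect in this assay is unknown; a step of modest size, within the scatter, is expected for compound 3 a number 1.2 percentage points lower from compound 2 to compound 3 (within the scatter). Compound 3 is therefore estimated at 74%, between 60% and 86%.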

Compound 3, a percentage reported as inhibition, at one concentration (the size of the read-out at that concentration, not a potency): 64.3%
Estimate against measurement, compound 3: 9.7 percentage points above; measured number inside the range.
By their numbers in this assay, from the lowest: compounds 1 and 3 (each within the scatter of the next); then compound 2.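

In this assay the change from methyl to ethyl on a saturated chain carbon bound to an aromatic carbon gives a number 10.9 percentage points lower from compound 2 to compound 3 (beyond the scatter) and so shows that this single added carbon can change the read-out at this place. With ethyl present, carboxy in place of hydroxy on an aromatic carbon gives a number 1.1 percentage points higher from compound 1 to compound 3 (within the scatter) and so shows no clear effect in this one pair. Nothing available gives a reason for either result. On these data alone, whether a longer chain such as propyl would lower the number further stays open, as does how an amine in place of carboxy would compare.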